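The compounds below may be only part of what the source reports. "The series", "measured", "known", "first", "only" and "open" are said of these compounds alone.

Compound 2 `COc1ccc(CNC(=O)/C(C#N)=C/c2ccco2)cc1` carries an unsubstituted furan ring on the shared core, and in a functional assay on DU-145 cells (Homo sapiens) for inhibition, read by MTT assay, with a stated time of 72 h (a higher number here means a weaker inhibitor of growth, a lower number a stronger inhibitor of growth), compound 2 gives 29000 nM. Among the compounds with values here, that is the only plain number in the set. Compound 1 `N#C/C(=C\c1c(F)c(F)c(F)c(F)c1F)C(=O)c1ccc[nH]1`, built on a different core, reaches only a limit of the assay, and in this assay compound 1 gives > 100000 nM. Compound 3 `COc1ccc(CNC(=O)/C(C#N)=C/c2ccc(-c3ccccc3)o2)cc1`, in which a phenyl replaces a hydrogen on the furan ring, likewise reaches only a limit, and in this assay compound 3 gives > 100000 nM. Within the data shown here, compound 2 therefore stands as the single measured value, with two of the three compounds sitting at the limit of > 100000 nM in this assay, at which 2 of the 3 values shown sit.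

Compound 4 `COc1ccc(CNC(=O)/C(C#N)=C/c2cc(Br)co2)cc1` differs from compound 2 in one place: bromo in place of hydrogen on an aromatic carbon. Among the measured compounds shown here, the one measured step that bears on this is an at least 3.4-fold higher number from compound 2 to compound 3 (0.53 log units; beyond the scatter), where a phenyl entered on the same furan ring, though at another aromatic carbon. For the measured compounds named here, a bromo is a single heavy atom rather than a ring, so a smaller shift is plausible, but the only precedent points toward a higher number. The step expected from compound 2 to compound 4 is a 1.7-fold higher number from compound 2 to compound 4 (0.24 log units; within the scatter), a modest weakening of growth inhibition. The estimated value of compound 4 in this assay is 50000 nM, with a range from 15000 nM to 150000 nM.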

Compound 4, concentration for 50% growth inhibition: 61000 nM
Beside the measured number, compound 4's estimate is 1.2-fold (0.09 log units) below it, and the stated range covers the measured number.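

In this assay, the change reads as a 2.1-fold higher number from compound 2 to compound 4 (0.32 log units; beyond the scatter), so a single bromo, with no ring, set on the aromatic carbon two ring bonds from the ring oxygen is enough to move the number modestly toward a weaker inhibitor of growth. Within the data shown here, this is the first step on the shared core with a plain number at both ends, so its size can be read directly, whereas the earlier step to the phenyl compound ends at a limit of the assay. Compound 4 also keeps a plain number and does not join the compounds held at that limit: the limit of > 100000 nM in this assay, at which 2 of the 4 values shown sit.

The compounds shown leave open whether this shift belongs to bromine itself or would follow any group on this carbon, such as a chloro, a methyl, an amine or a carboxylic acid. They also leave open whether any replacement of a hydrogen on the furan ring of compound 2 can give a lower number rather than a higher one, since both steps shown point the same way.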